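This account rests on a few compounds, and the source may have more. Where it says the series, first, only, none or still open, it means among the compounds named here.

Measured compounds in the series:

- Compound 1, `Fc1cccc(-c2nc(Nc3ccccc3)c3ccccc3n2)c1`. In a functional assay on HT29-AK cells (Homo sapiens) for cytotoxicity, read by MTT assay, with a stated time of 48 h (on this read-out higher numbers stand for weaker inhibition and lower numbers for stronger inhibition), compound 1 gives > 50000 nM, which is a limit of the assay and not a number.
- Compound 2, `Fc1ccc(Nc2nc(-c3cccc(F)c3)nc3ccc(F)cc23)cc1`. In this assay compound 2 gives > 50000 nM, again a limit of the assay.
- Compound 3, `Fc1cccc(-c2nc(Nc3ccccc3Cl)c3cc(F)ccc3n2)c1`. In this assay compound 3 gives > 50000 nM, also a limit of the assay.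

Compound 2 therefore stands only at a limit in this assay, with no number of its own. The two further values in the set are likewise limits, so nothing ranks compound 2 against compound 1 or compound 3.

The unmeasured compound 4 is `Fc1cccc(-c2nc(Nc3ccc(Br)cc3)c3cc(F)ccc3n2)c1`. It differs from compound 2 by bromo in place of fluoro on an aromatic carbon.

Within the data shown here, the single measured step that touches compound 2, a step that the two limits leave unreadable from compound 2 to compound 3, runs from one limit to another and gives no size. The same holds for the set as a whole, since (the limit of > 50000 nM in this assay, at which 3 of the 3 values shown sit). No readable step bears on the change from compound 2 to compound 4, so no size in this assay can be taken from the data, in either direction.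

Compound 4 is accordingly expected to sit at the limit too, estimated at 80000 nM with a range of 20000 nM to 300000 nM. The step that the limit leaves unreadable from compound 2 to compound 4 is thus expected to be nothing beyond the scatter.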

Compound 4, half-maximal inhibitory concentration: > 50000 nM
Compound 4 ended at the assay's limit; the forecaster's own chance of this, stated with the estimate: 85%; the middle value is on the limit's open side.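

In this assay no new step can be read for compound 4 against compound 2 or compound 3, because each pair runs from one limit to another: the limit of > 50000 nM in this assay, at which 4 of the 4 values shown sit.

The compounds shown leave open what size any of these changes, bromo in place of fluoro among them, has in this assay: none of the compounds carries a number of its own.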